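The source may report more compounds than this note shows. Statements on the series, on what has been measured and on what is new or still open speak of the compounds shown alone.

Measured so far in a physicochemical assay for solubility; on this read-out higher numbers stand for higher solubility and lower numbers for lower solubility:
compound 1 `O=C(c1ccc(Cl)cc1)N1CCC(NS(=O)(=O)c2cc(S(=O)(=O)c3ccccc3)ccc2C(F)(F)F)CC1` gives 3100 nM
compound 2 `O=C(c1ccc(Cl)nc1)N1CCC(NS(=O)(=O)c2cc(S(=O)(=O)c3ccccc3)ccc2C(F)(F)F)CC1` gives 25000 nM
compound 3 `CN(C)c1ccc(C(=O)N2CCC(NS(=O)(=O)c3cc(S(=O)(=O)c4ccccc4)ccc3C(F)(F)F)CC2)cn1` gives 12500 nM

Compound 2 has the highest of the three numbers in this assay. Its gap to compound 3 lies within the scatter, so those two cannot be ordered, while its gap to compound 1 is clear: an 8.1-fold higher number from compound 1 to compound 2 (0.91 log units; beyond the scatter). Compound 4 `O=C([C@@H]1CCNC1)N1CCC(NS(=O)(=O)c2cc(S(=O)(=O)c3ccccc3)ccc2C(F)(F)F)CC1` has not yet been measured. The change from compound 2 to compound 4: pyrrolidin-3-yl in place of 6-chloropyridin-3-yl on a carbonyl carbon.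

Within the data shown here, two measured steps bear on this, the two that also alter the group on the carbonyl carbon: an 8.1-fold higher number from compound 1 to compound 2 (0.91 log units; beyond the scatter) and a 4.0-fold higher number from compound 1 to compound 3 (0.61 log units; beyond the scatter), both modest and both upward. The third step, a 2.0-fold lower number from compound 2 to compound 3 (0.30 log units; within the scatter), is within the scatter. None of the three replaces an aromatic ring with a non-aromatic one carrying a hydrogen-bond donor, so the present change is not covered directly. What the data do show is that changing the group on the carbonyl carbon has so far moved this assay upward from compound 1 by modest amounts and has not lowered it. An upward step beyond the scatter is therefore expected, with wide uncertainty. For compound 4 the estimated value is 60000 nM (range 12000 nM to 300000 nM), which corresponds to an expected step of a 2.4-fold higher number from compound 2 to compound 4 (0.38 log units; beyond the scatter).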

Compound 4, solubility: 12500 nM
For compound 4 the middle estimate is 4.8-fold (0.68 log units) above the measured one, and the stated range covers the measured number.
By their numbers in this assay, from the lowest: compound 1; then compounds 3, 4 and 2 (each within the scatter of the next).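

In this assay an aromatic ring on the carbonyl carbon proves unnecessary for a number clear of the 4-chlorophenyl compound: with pyrrolidin-3-yl, a five-membered non-aromatic ring carrying a hydrogen-bond donor and a defined stereocentre, the result is a 4.0-fold higher number from compound 1 to compound 4 (0.61 log units; beyond the scatter). Against the two pyridine groups there is no separation, with a 2.0-fold lower number from compound 2 to compound 4 (0.30 log units; within the scatter) and no change at the digits printed from compound 3 to compound 4 (within the scatter), so compound 2, compound 3 and compound 4 cannot be ordered, and replacing either aromatic ring with this non-aromatic one shows no change beyond the scatter. Nothing at hand explains why these three different groups cannot be told apart.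

Open, on these data alone, is whether the hydrogen-bond donor or the defined stereocentre of pyrrolidin-3-yl has any bearing on the reading in this assay, and how the mirror-image pyrrolidin-3-yl would compare. Equally open, as far as these compounds go, is how a cyclopentyl ring, which lacks the ring nitrogen, or a carboxylic acid on a short chain would read at this carbonyl carbon relative to compound 4.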